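Swapping the dimethylisoxazole for a pyridine on the sulfonyl

A few compounds are considered here, and "the series" means these few. Any claim that something is new, unique, unknown or untested is made for them only; others in the source may bear on it.

The compounds share one core: a sulfonamide built on two linked saturated rings, with a methyl-bearing ring at one end and an aromatic group on the sulfonyl sulfur at the other. Compound 1 `Cc1noc(C)c1S(=O)(=O)N1CCC(N2CCC(C)CC2)CC1` carries a 3,5-dimethyl-1,2-oxazol-4-yl group there. In a functional assay on DLD-1 cells (Homo sapiens) for antiproliferative activity, read by CellTiter-Glo, with a stated time of 72 h (a higher number here means a weaker inhibitor, a lower number a stronger inhibitor), compound 1 gives only a limit, > 5000 nM, so no exact figure is known for it. Compound 2 `CC1CCN(C2CCN(S(=O)(=O)c3cccc4ccccc34)CC2)CC1` carries a naphthalene on the same sulfur, and in this assay compound 2 gives 0.65 nM. Compound 1 sits at the limit of > 5000 nM in this assay, at which 1 of the 2 values shown sits. Compound 3 `CC1CCN(C2CCN(S(=O)(=O)c3cccnc3)CC2)CC1` makes one change to compound 1: pyridin-3-yl in place of 3,5-dimethyl-1,2-oxazol-4-yl on a sulfonyl sulfur. A step toward stronger inhibition is expected, an at least 2.0-fold lower number from compound 1 to compound 3 (0.30 log units; that floor lies within the scatter), but modest and uncertain. Compound 3 is estimated at 2500 nM, within a range from 300 nM to 20000 nM.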

Compound 3, half-maximal inhibitory concentration: 2400 nM
For compound 3 the middle estimate is 1.0-fold (0.02 log units) above the measured one, and the stated range covers the measured number.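

In this assay compound 3 gives 2400 nM, the first exact figure shown for a group on the sulfonyl sulfur other than naphthalene. Placing pyridin-3-yl in place of 3,5-dimethyl-1,2-oxazol-4-yl produces an at least 2.0-fold lower number from compound 1 to compound 3 (0.31 log units; beyond the scatter), so exchanging one aromatic ring for another at this position can move the result beyond the scatter. That step is only a floor and its true size remains unknown, because one end of it is a limit and not a number: the limit of > 5000 nM in this assay, at which 1 of the 3 values shown sits.

From the compounds shown here alone, what separates compound 3 from compound 2, which gives 0.65 nM with its naphthalene, remains open, and a plain phenyl ring on the sulfur would help to show it. Also unresolved is how a pyridine carrying an amine or a chlorine atom would behave, and what the methyl-bearing ring at the other end contributes.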